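This account rests on a few compounds, and the source may have more. Where it says the series, first, only, none or still open, it means among the compounds named here.

Working notes on the series.

Two compounds have numbers in a functional assay on the whole organism (strain Wistar albino) for inhibition, with Rattus norvegicus as the target, read by paw edema, with a stated time of 1 h, at a dose of 25 mg/kg by the oral route; on this read-out lower numbers stand for less inhibition and higher numbers for more inhibition at the one dose given (going by the name of the read-out). Compound 1 `CSc1nn(-c2ccc(S(N)(=O)=O)cc2)c2nc(Nc3ccccc3)n(-c3ccccc3)c(=O)c12` gives 68.9% in this assay. Compound 2 `O=c1c2c(Nc3ccccc3)nn(-c3ccc([N+](=O)[O-])cc3)c2nc(Nc2ccccc2)n1-c1ccccc1` gives 43.9% in this assay, the lowest of the two numbers, the gap to compound 1 lying beyond the usual scatter. Compound 1 and compound 2 differ in more than one place, so only their two values are set side by side here.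

Compound 3 `NS(=O)(=O)c1ccc(-n2nc(Nc3ccccc3)c3c(=O)n(-c4ccccc4)c(Nc4ccccc4)nc32)cc1` has not yet been measured in this assay. It differs from compound 2 by sulfamoyl in place of nitro on an aromatic carbon, that is, 4-nitrophenyl to 4-sulfamoylphenyl. Among the measured compounds shown here, no single-change step between measured compounds exists to calibrate this change. A step upward beyond the scatter is nevertheless expected from compound 2 to compound 3, because in this assay compound 1, which also carries a sulfamoyl group, gives 68.9%. The expected step is a number 16.1 percentage points higher from compound 2 to compound 3 (beyond the scatter). For compound 3 the estimate in this assay is 60%, with a range from 46% to 74%.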

Compound 3, a percentage reported as inhibition, in the whole organism at one dose (the size of the read-out at that dose, not a potency): 60.2%
Compound 3: the middle estimate sits 0.2 percentage points below what was measured; measured number inside the range.
By their numbers in this assay, from the lowest: compound 2; then compounds 3 and 1 (each within the scatter of the next).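

The change from 4-nitrophenyl to 4-sulfamoylphenyl now has its first single-change reading in this assay: with the rest of the structure held, the step is a number 16.3 percentage points higher from compound 2 to compound 3 (beyond the scatter) and so can be told apart from repeat scatter. With 4-sulfamoylphenyl held, anilino in place of methylsulfanyl on an aromatic carbon gives a number 8.7 percentage points lower from compound 1 to compound 3 (within the scatter) and so cannot be told apart from that scatter at this one dose. Nothing on hand bears on what lies behind either step.

Going by these compounds, only nitro and sulfamoyl are seen at this place, so it stays open how an amine, a carboxylic acid or a methoxy group there would read. Also open, on these data alone, is whether the same change would give a step of like size with methylsulfanyl in place of anilino.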